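A few compounds are considered here, and "the series" means these few. Any claim that something is new, unique, unknown or untested is made for them only; others in the source may bear on it.

In a functional assay on QGY-7703 cells (Homo sapiens) for cytotoxicity, read by MTT assay, with a stated time of 24 h (a lower number here means a stronger inhibitor, a higher number a weaker inhibitor), compound 1 `CN1C/C(=C\c2cccnc2)C(=O)/C(=C/c2ccccc2F)C1` gives 4470 nM, compound 3 `CN1C/C(=C\c2cccnc2)C(=O)/C(=C/c2ccc(F)cc2Br)C1` gives 2610 nM, and compound 2 `CN1C/C(=C\c2cccnc2)C(=O)/C(=C/c2cc([N+](=O)[O-])ccc2F)C1` gives 11100 nM. Compound 1 thus lies within the scatter of compound 3, while compound 2 stands clearly higher than compound 1. Compound 4 `O=C1/C(=C/c2cccnc2)CNC/C1=C\c1ccccc1F` differs from compound 1 in one place: hydrogen in place of methyl on an amine nitrogen in a ring. The two measured steps, a 2.5-fold higher number from compound 1 to compound 2 (0.40 log units; beyond the scatter) and a 1.7-fold lower number from compound 1 to compound 3 (0.23 log units; within the scatter), both alter the 2-fluorophenyl group and leave this nitrogen untouched, so they offer only a rough guide to step size. No direction can be argued, and no step beyond the scatter is expected. The expected step is a 1.1-fold lower number from compound 1 to compound 4 (0.05 log units; within the scatter). For compound 4 the estimated value is 4000 nM, with an expected range of 1500 nM to 11000 nM.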

Compound 4, half-maximal inhibitory concentration: 8890 nM
Compound 4: the middle estimate sits 2.2-fold (0.35 log units) below what was measured; the range from low to high includes it.
By their numbers in this assay, from the lowest: compounds 3, 1, 4 and 2 (each within the scatter of the next, the first and the last beyond it).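

Among the compounds shown here, this is the first change at the ring nitrogen rather than on the 2-fluorophenyl group. In this assay, hydrogen in place of methyl on this amine nitrogen gives a 2.0-fold higher number from compound 1 to compound 4 (0.30 log units; within the scatter), so on this one pair, removing the methyl produces no step beyond the scatter. Nothing available explains this result.

Still open, as far as these compounds go, is how larger groups on this nitrogen, such as an ethyl, a benzyl or an acetyl group, would behave. From the compounds shown here alone, it is also open whether the same swap gives a similar step alongside the 2-bromo-4-fluorophenyl group of compound 3.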